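The source may hold more compounds than are shown below. What is called first, only, known or untested is meant among the compounds shown, and "the series" means these compounds.

In a functional assay on HEp-2 cells (Homo sapiens) for inhibition (a lower number here means that less compound is needed, a higher number that more compound is needed for the effect), two compounds with the same core have been measured so far. Compound 1 `CCSc1ncnc2c1nnn2[C@@H]1O[C@H](CO)[C@@H](O)[C@H]1O` gives 0.1 uM, and compound 2 `COc1ncnc2c1nnn2[C@@H]1O[C@H](CO)[C@@H](O)[C@H]1O` gives 0.3 uM, the higher of the two numbers. Compound 3 `CCOc1ncnc2c1nnn2[C@@H]1O[C@H](CO)[C@@H](O)[C@H]1O` differs from compound 2 by one change: methyl in place of hydrogen on a saturated chain carbon bound to an oxygen on an aromatic ring. In words, this is methyl in place of hydrogen on a saturated chain carbon bound to an oxygen on an aromatic ring, which turns methoxy into ethoxy.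

For the measured compounds named here, only one measured step bears on this, and only indirectly: a 3.0-fold higher number from compound 1 to compound 2 (0.48 log units; beyond the scatter). That step changes sulfur to oxygen and ethyl to methyl together, and the data do not separate the two. Going by the values given here, compound 3 keeps the oxygen of compound 2 and takes on the ethyl of compound 1, so it may recover part of that modest step, though no measured pair isolates the added methyl. The expected result is a slight move toward a lower number, not one beyond the scatter: a 1.5-fold lower number from compound 2 to compound 3 (0.18 log units; within the scatter). For compound 3 the estimated value is 0.2 uM, with an expected range from 0.07 uM to 0.6 uM.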

Compound 3, concentration for half-maximal effect: 0.1 uM
Beside the measured number, compound 3's estimate is 2.0-fold (0.30 log units) above it, and the stated range covers the measured number.
By their numbers in this assay, from the lowest: compounds 1 and 3 (each within the scatter of the next); then compound 2.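

In this assay, the added methyl alone is enough to move the number beyond the scatter (a 3.0-fold lower number from compound 2 to compound 3 (0.48 log units; beyond the scatter)), so the length of the chain on this oxygen matters, at least in going from methoxy to ethoxy. With the ethyl held constant, ethoxy in place of ethylsulfanyl gives no difference (no change at the digits printed from compound 1 to compound 3 (within the scatter)), which separates the two changes that were tied together in the earlier step: for these ethyl compounds, the choice of oxygen or sulfur makes no difference at the digits printed, and the gap between compound 1 and compound 2 matches the one that the methyl alone produces. The data offer no explanation for either of these results.

The compounds shown leave open whether the trend continues beyond ethyl, to a longer chain such as propoxy or a branched one such as isopropoxy, or whether ethyl is already the end of it. They also leave open whether methylsulfanyl would show the same gap from ethylsulfanyl, and how an amine on this aromatic carbon would compare with the oxygen and sulfur groups.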